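A Phenyl Swap Tested Twice on a Shared Core

A few compounds are considered here, and "the series" means these few. Any claim that something is new, unique, unknown or untested is made for them only; others in the source may bear on it.

Three measured compounds share one core and differ at two places. Compound 1 `CNC(=O)c1cc(Oc2ccc(NC(=O)c3cc4cccnc4n(-c4ccc(C(F)(F)F)cc4Cl)c3=O)cc2)ccn1` is the reference; in a functional assay on A549 cells (Homo sapiens) for antiproliferative activity, read by MTT assay, with a stated time of 72 h (on this read-out lower numbers stand for stronger inhibition and higher numbers for weaker inhibition), compound 1 gives 2090 nM. Compound 2 `CNC(=O)c1cc(Oc2ccc(NC(=O)c3cc4cccnc4n(-c4ccc(F)c(Cl)c4)c3=O)cc2)ccn1` differs from compound 1 in one place: 3-chloro-4-fluorophenyl in place of 2-chloro-4-(trifluoromethyl)phenyl on an aromatic nitrogen. That change gave a 1.3-fold lower number from compound 1 to compound 2 (0.13 log units; within the scatter). In this assay compound 2 gives 1560 nM. Compound 3 `CCCNC(=O)c1cc(Oc2ccc(NC(=O)c3cc4cccnc4n(-c4ccc(C(F)(F)F)cc4Cl)c3=O)cc2)ccn1` keeps the 2-chloro-4-(trifluoromethyl)phenyl group of compound 1 but carries propylcarbamoyl instead of methylcarbamoyl, and in this assay compound 3 gives 1250 nM, which is a 1.7-fold lower number from compound 1 to compound 3 (0.22 log units; within the scatter).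

Compound 4 `CCCNC(=O)c1cc(Oc2ccc(NC(=O)c3cc4cccnc4n(-c4ccc(F)c(Cl)c4)c3=O)cc2)ccn1` has not yet been measured. It differs from compound 3 as follows: 3-chloro-4-fluorophenyl in place of 2-chloro-4-(trifluoromethyl)phenyl on an aromatic nitrogen. The core of compound 3 differs from the core of compound 1 in one place: ethyl in place of hydrogen on a saturated chain carbon bound to an amide-type nitrogen. The surroundings of the swapped group are the same in both pairs, so this is the same change made a second time, on a slightly different core. Because the first instance gave a 1.3-fold lower number from compound 1 to compound 2 (0.13 log units; within the scatter), a step of about a 1.3-fold lower number from compound 3 to compound 4 (0.10 log units; within the scatter) is expected this time as well. Compound 4 is therefore estimated at 1000 nM, most likely between 500 nM and 2000 nM.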

Compound 4, half-maximal inhibitory concentration: 590 nM
Beside the measured number, compound 4's estimate is 1.7-fold (0.23 log units) above it; measured number inside the range.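

In this assay, the phenyl swap gave a 2.1-fold lower number from compound 3 to compound 4 (0.33 log units; beyond the scatter), and its size does not differ measurably from that of the earlier instance: the same change on two cores in this assay, a 1.3-fold lower number (0.13 log units; within the scatter) from compound 1 to compound 2 and a 2.1-fold lower number (0.33 log units; beyond the scatter) from compound 3 to compound 4, 1.6-fold (0.20 log units) apart, within the scatter of two such steps

Replacing methylcarbamoyl with propylcarbamoyl gave a 2.6-fold lower number from compound 2 to compound 4 (0.42 log units; beyond the scatter), and this step also matches its earlier instance: the same change on two cores in this assay, a 1.7-fold lower number (0.22 log units; within the scatter) from compound 1 to compound 3 and a 2.6-fold lower number (0.42 log units; beyond the scatter) from compound 2 to compound 4, 1.6-fold (0.20 log units) apart, within the scatter of two such steps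

Among the compounds shown here, each change therefore lowered the number on both cores, although only the steps reaching compound 4 lie beyond the scatter; this single pair of instances per change does not prove that the steps are identical in size or that either change would behave alike on another core.

Going by these compounds, it remains open whether a longer chain such as butyl, or a propyl chain ending in an amine, would carry the trend further. The swap also alters the chlorine position and replaces trifluoromethyl with fluorine at once, so the part played by each remains unresolved, as does the outcome with a phenyl ring bearing a nitrile or methoxy group.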